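The source may hold more compounds than are shown below. What is called first, only, known or untested is meant among the compounds shown, and "the series" means these compounds.

In a functional assay on the whole organism for positive allosteric modulation, with Mus musculus as the target (on this read-out lower numbers stand for an effect already at smaller amounts and higher numbers for an effect only at larger amounts of compound), compound 3 `CCC(=O)N(c1cccc(Cl)c1)C1CCCC1N(C)C` gives 20 mg/kg, the higher of the two values in the series that are actual numbers. Within the data shown here, compound 1 `CCC(=O)N(c1cccc(F)c1)C1CCCC1N(C)C` gives 5 mg/kg, and the only measured step is a 4.0-fold higher number from compound 1 to compound 3 (0.60 log units; beyond the scatter). Compound 2 `CCC(=O)N(c1ccc(F)cc1)C1CCCC1N(C)C`, whose fluoro is para to a large group, reaches only a limit, > 50 mg/kg. Compound 4 `CCC(=O)N(c1ccc(F)c(Cl)c1)C1CCCC1N(C)C` differs from compound 3 by one change, fluoro in place of hydrogen on an aromatic carbon, ortho to a chloro group and para to a large group. Among the measured compounds shown here, no measured step isolates this change, so the limit of compound 2 is the closest guide, and it points towards a higher number. The expected step, of modest size, is a 2.3-fold higher number from compound 3 to compound 4 (0.35 log units; beyond the scatter). Compound 4 is estimated at 45 mg/kg, within a range from 15 mg/kg to 130 mg/kg.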

Compound 4, dose for half-maximal effect: 0.7 mg/kg
The estimate for compound 4 lay 64-fold (1.81 log units) above the measured number; measured number outside the range, below it.
By their numbers in this assay, from the lowest: compound 4; then compound 1; then compound 3. At a limit, above all of these: compound 2.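

In this assay, fluoro para to a large group does not lead to a high number when a chloro group sits ortho to it, giving a 29-fold lower number from compound 3 to compound 4 (1.46 log units; beyond the scatter). Adding that chloro group to the fluoro compound gives an at least 71-fold lower number from compound 2 to compound 4 (1.85 log units; beyond the scatter), so the outcome of fluoro at this position depends on its neighbour. The reference for that step is a limit, not a number: the limit of > 50 mg/kg in this assay, at which 1 of the 4 values shown sits.

On these data alone, it remains open whether a bromo or methyl group in place of the chloro would serve equally well. As far as these compounds go, whether a nitrile or methoxy group could replace the fluoro at this position is also open.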